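Swapping a Benzylamino Group for Methoxy

The compounds below may be only part of what the source reports. "The series", "measured", "known", "first", "only" and "open" are said of these compounds alone.

Of the compounds shown here, three sharing one core have been measured in a functional assay on HEY cells (Homo sapiens) for cytotoxicity, read by MTT assay, with a stated time of 72 h; a higher number here means a weaker inhibitor, a lower number a stronger inhibitor. Compound 1 `N[C@H]1CC[C@H](Nc2c(C(=O)NCc3ccc(Oc4ccccc4)cc3)nc(Br)c3cccnc23)CC1` gives 9000 nM, compound 2 `COc1ccc(CNC(=O)c2nc(Br)c3cccnc3c2N[C@H]2CC[C@H](N)CC2)cc1` gives 4000 nM, and compound 3 `CN(C)c1ccc(CNC(=O)c2nc(Br)c3cccnc3c2N[C@H]2CC[C@H](N)CC2)cc1` gives 5300 nM. Compound 2 separates clearly only from compound 1, as a 2.3-fold lower number from compound 1 to compound 2 (0.35 log units; beyond the scatter) shows, whereas a 1.3-fold higher number from compound 2 to compound 3 (0.12 log units; within the scatter) and a 1.7-fold lower number from compound 1 to compound 3 (0.23 log units; within the scatter) are too small to count as real differences.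

Compound 4 `COC(=O)c1nc(Br)c2cccnc2c1N[C@H]1CC[C@H](N)CC1` makes a much larger change: methoxy in place of (4-methoxybenzyl)amino on a carbonyl carbon. In other words, methoxy replaces (4-methoxybenzyl)amino on a carbonyl carbon, and the aromatic ring of that group goes with it. The three measured steps only exchange one group on that ring, so they are a weak guide, and none shows what losing the ring does. The largest of them is still modest, and a step of similar size toward a higher number is a cautious expectation, with the direction uncertain. The expected change is a 2.3-fold higher number from compound 2 to compound 4 (0.35 log units; beyond the scatter). For compound 4 the estimated value is 9000 nM, with an expected range from 2500 nM to 30000 nM.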

Compound 4, half-maximal inhibitory concentration: > 20000 nM
Compound 4 ended at the assay's limit (the forecaster's own chance of this, stated with the estimate: 15%); middle value at least 2.2-fold (0.34 log units) away from the limit.
By their numbers in this assay, from the lowest: compounds 2, 3 and 1 (each within the scatter of the next, the first and the last beyond it). At a limit, above all of these: compound 4.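

In this assay compound 4 gives > 20000 nM, which is a limit of the assay and not a number. Exchanging the whole (4-methoxybenzyl)amino group for methoxy on the carbonyl carbon, aromatic ring included, gives an at least 5.0-fold higher number from compound 2 to compound 4 (0.69 log units; beyond the scatter), so this position responds to the loss of that group more strongly than the earlier swaps on the ring suggested. The result fixes only the lower edge of this step, and its full size cannot be read: the limit of > 20000 nM in this assay, at which 1 of the 4 values shown sits.

The compounds shown leave open whether the change depends on the lost aromatic ring, the lost amide hydrogen or simply the smaller group. A methylamino group or a plain benzylamino group on the same carbonyl carbon would help separate these possibilities.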